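Changing the oxan-4-yl group of compound 3

The compounds below may be only part of what the source reports. "The series", "measured", "known", "first", "only" and "open" are said of these compounds alone.

Compound 1 `C[C@@H](c1ccc(NC(=O)N2CC(c3cccnc3)C2)cc1)N1Cc2ccccc2C1=O`: 1.5 nM
Compound 2 `C[C@H](NC(=O)c1ncccn1)c1ccc(NC(=O)N2CC(c3cccnc3)C2)cc1`: 36 nM
Compound 3 `C[C@H](NC(=O)C1CCOCC1)c1ccc(NC(=O)N2CC(c3cccnc3)C2)cc1`: 17 nM

In a functional assay on A2780 cells (Homo sapiens) for antiproliferative activity, read by CellTiter-Glo, with a stated time of 72 h (on this read-out lower numbers stand for stronger inhibition and higher numbers for weaker inhibition), compound 3 gives 17 nM as the second highest of the three numbers. Compound 4 `C[C@H](NC(=O)[C@@H]1CCCN1C)c1ccc(NC(=O)N2CC(c3cccnc3)C2)cc1` differs from it by 1-methylpyrrolidin-2-yl in place of oxan-4-yl on a carbonyl carbon and so has 1-methylpyrrolidin-2-yl in place of oxan-4-yl on a carbonyl carbon. The step of a 2.1-fold lower number from compound 2 to compound 3 (0.33 log units; beyond the scatter) is modest and swaps a group on the same kind of carbonyl carbon, which makes it the closest evidence. The steps of a 24-fold higher number from compound 1 to compound 2 (1.38 log units; beyond the scatter) and an 11-fold higher number from compound 1 to compound 3 (1.05 log units; beyond the scatter) are large but change a group on a saturated chain carbon instead. For the measured compounds named here, no measured compound carries the new group. A modest step towards a higher number is expected in this assay for this change. The estimate means a 1.8-fold higher number from compound 3 to compound 4 (0.25 log units; within the scatter) as the expected step. Compound 4 is estimated at 30 nM with a range from 8 nM to 110 nM expected.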

Compound 4, half-maximal inhibitory concentration: 5.7 nM
Beside the measured number, compound 4's estimate is 5.3-fold (0.72 log units) above it; the measured number lies below the stated range.
By their numbers in this assay, from the lowest: compound 1; then compound 4; then compound 3; then compound 2.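

On the carbonyl carbon, 1-methylpyrrolidin-2-yl gives the lowest number of the three groups shown there in this assay, improving on oxan-4-yl (a 3.0-fold lower number from compound 3 to compound 4 (0.47 log units; beyond the scatter)) and by more on pyrimidin-2-yl (a 6.3-fold lower number from compound 2 to compound 4 (0.80 log units; beyond the scatter)). Even so, this amide group does not match the group on the saturated chain carbon of compound 1 (a 3.8-fold higher number from compound 1 to compound 4 (0.58 log units; beyond the scatter)). No measurement here accounts for the gain.

The compounds shown leave open whether the gain depends on the ring nitrogen, its methyl group or the defined stereocentre. From the compounds shown here alone, whether pyrrolidin-2-yl without the methyl, or an open-chain amine such as dimethylaminomethyl, would do the same also remains open.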